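Working notes: from compound 1 to compound 4

The source may hold more compounds than are shown below. What is called first, only, known or untested is meant among the compounds shown, and "the series" means these compounds.

The shared core is carried by compound 1 `Nc1cc(N)c2nc(-c3ccccc3)c(Sc3ccc(F)cc3)nc2c1`, compound 2 `COc1cc(CNc2nc3cc(N)cc(N)c3nc2-c2ccccc2)cc(OC)c1OC` and compound 3 `CCOC(=O)[C@H](CCC(=O)O)NC(=O)c1ccc(Oc2nc3cc(N)cc(N)c3nc2-c2ccccc2)cc1`, all tested in a functional assay on A498 cells (Homo sapiens) for inhibition, read by sulforhodamine B assay, with a stated time of 48 h; on this read-out higher numbers stand for lower toxicity in this test and lower numbers for higher toxicity in this test. For compound 1 the read-out is only a limit, < 100000 nM, so compound 1 stands at the limit described by the limit of < 100000 nM in this assay, at which 1 of the 3 values shown sits, and no number is fixed for it. Compound 2 gives 33900 nM in this assay. Compound 3 gives 33900 nM in this assay; the two values of compound 2 and compound 3 are the same.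

Compound 4 `Nc1cc(N)c2nc(-c3ccccc3)c(NCc3ccc(F)cc3)nc2c1` is not yet measured. It differs from compound 1 by (4-fluorobenzyl)amino in place of (4-fluorophenyl)sulfanyl on an aromatic carbon. The entering group brings one hydrogen-bond donor where the leaving group had none, and one more heavy atom.

Going by the values given here, no step between measured compounds is available, and compound 1 offers only a limit, so the size of the step cannot be sized from data. The step that the limit leaves unreadable from compound 1 to compound 4 is expected to stay within the scatter, with no direction favoured. Compound 4 is expected to give about 35000 nM in this assay, between 10000 nM and 100000 nM.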

Compound 4, concentration lethal to 50% of the cells: 57500 nM
The estimate for compound 4 lay 1.6-fold (0.22 log units) below the measured number; measured number inside the range.
By their numbers in this assay, from the lowest: compounds 2, 3 and 4 (each within the scatter of the next).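

No step can be read from compound 1 to compound 4 in this assay, because compound 1 carries only a limit and no number: the limit of < 100000 nM in this assay, at which 1 of the 4 values shown sits.

The compounds shown leave open whether (4-fluorobenzyl)amino in place of (4-fluorophenyl)sulfanyl on the shared core changes this read-out, and in which direction.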